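Swapping methoxy for fluoro on the styryl ring of compound 3

The source may report more compounds than this note shows. Statements on the series, on what has been measured and on what is new or still open speak of the compounds shown alone.

The series consists of three measured oxime-bearing compounds. Compound 1 `COc1ccc(C(/C=C/c2ccc(F)cc2)=N/O)cc1` gives 11000 nM in a functional assay (Mus musculus, strain Balb/c) for inhibition, read by ELISA, with a stated time of 72 h (on this read-out higher numbers stand for weaker inhibition and lower numbers for stronger inhibition), compound 2 `Cc1ccc(C(/C=C/c2ccc(Br)cc2)=N/O)cc1` gives 11600 nM, and compound 3 `COc1ccc(/C=C/C(=N\O)c2ccc(C)cc2)cc1` gives 6240 nM. On these numbers compound 3 holds the lowest value, yet its gaps to compound 1 and to compound 2 both fall within the usual scatter, so no ordering among the three can be claimed. Within the data shown here, the one single-point step on record is a 1.9-fold lower number from compound 2 to compound 3 (0.27 log units; within the scatter).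

Compound 4 `Cc1ccc(C(/C=C/c2ccc(F)cc2)=N/O)cc1` differs from compound 3 as follows: fluoro in place of methoxy on an aromatic carbon. Among the measured compounds shown here, no measured pair carries exactly this exchange, so the only guidance is indirect: the bromo-to-methoxy step at the same position was within the scatter, and every compound here sits in a narrow band. Compound 4 is therefore expected to remain in that band, with an estimated step of a 1.6-fold higher number from compound 3 to compound 4 (0.20 log units; within the scatter). The expected value for compound 4 is 10000 nM, within a range from 4000 nM to 25000 nM.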

Compound 4, half-maximal inhibitory concentration: 11300 nM
For compound 4 the middle estimate is 1.1-fold (0.05 log units) below the measured one; the measured number falls inside the stated range.
By their numbers in this assay, from the lowest: compounds 3, 1, 4 and 2 (each within the scatter of the next).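

At this aromatic carbon, para to a large group, fluoro in place of methoxy gives a 1.8-fold higher number from compound 3 to compound 4 (0.26 log units; within the scatter) and fluoro in place of bromo gives a 1.0-fold lower number from compound 2 to compound 4 (0.01 log units; within the scatter) in this assay, so the numbers do not separate methoxy, bromo and fluoro at this place. A second place on the core now has a reading of its own, since methyl in place of methoxy there gives a 1.0-fold higher number from compound 1 to compound 4 (0.01 log units; within the scatter) with the fluoro held fixed. No supporting data bear on these results.

Going by these compounds, it stays open whether an amine or a carboxylic acid on this aromatic carbon would give a step beyond the scatter. On these data alone, it also stays open what a carbonyl in place of the oxime would do to the number.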